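Ester and Saturated Chain in Place of the Acrylic Acid

The source may report more compounds than this note shows. Statements on the series, on what has been measured and on what is new or still open speak of the compounds shown alone.

The study measures inhibition in an assay on a protein complex for inhibition of CDK8/Cyclin C (Homo sapiens), with a stated time of 1 h; a higher number here means a weaker inhibitor, a lower number a stronger inhibitor. Within the data shown here, compound 1 `O=C(O)/C=C/c1ccncc1-c1ccc2ccccc2c1` gives 5 nM, the lowest of the two numbers measured so far. Compound 2 `O=C(O)CCNC(=O)/C=C/c1ccncc1-c1ccc2ccccc2c1` gives 870 nM in this assay, and the change between them, (2-carboxyethyl)amino in place of hydroxy on a carbonyl carbon, produced a 170-fold higher number from compound 1 to compound 2 (2.24 log units; beyond the scatter).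

Compound 3 `COC(=O)CCc1ccncc1-c1ccc2ccccc2c1` has not yet been measured in this assay. It differs from compound 1 in one place: 2-(methoxycarbonyl)ethyl in place of 2-carboxyethenyl on an aromatic carbon. Among the measured compounds shown here, the one measured step that bears on this change is the step from compound 1 to compound 2, where the carboxylic acid of compound 1 was converted to an amide and the number rose by a 170-fold higher number from compound 1 to compound 2 (2.24 log units; beyond the scatter). In compound 3 the carboxylic acid is likewise no longer present, being replaced by a methyl ester, and the double bond outside the aromatic rings is also removed. A step in the same direction, of large size, is therefore expected, a 400-fold higher number from compound 1 to compound 3 (2.60 log units; beyond the scatter).

For compound 3 the estimated value in this assay is 2000 nM, with a range from 300 nM to 15000 nM.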

Compound 3, half-maximal inhibitory concentration: 259 nM
Beside the measured number, compound 3's estimate is 7.7-fold (0.89 log units) above it, outside the stated range (below it).
By their numbers in this assay, from the lowest: compound 1; then compound 3; then compound 2.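

Among these compounds, with compound 3, the change for the first time reaches the chain itself on the aromatic carbon opposite the ring nitrogen, whereas the earlier step altered only the group on the carbonyl carbon and kept the double bond in place. Putting 2-(methoxycarbonyl)ethyl in place of 2-carboxyethenyl gives a 52-fold higher number from compound 1 to compound 3 (1.71 log units; beyond the scatter) in this assay, so this second departure from compound 1 also raises the number by a large step, and compound 1 keeps the lowest number of the three. No measurement shown here explains the size of this step.

Since compound 3 differs from compound 1 in both the methyl ester and the saturated chain, the step cannot be divided between these two features. The matching 2-carboxyethyl group, a carboxylic acid on the saturated chain, and the 2-(methoxycarbonyl)ethenyl group, a methyl ester that keeps the double bond, would each separate one feature from the other, and the compounds shown leave open how either would read in this assay.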